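Shrinking a Phenyl to a Methyl on the Core

The source may hold more compounds than are shown below. What is called first, only, known or untested is meant among the compounds shown, and "the series" means these compounds.

Compound 1 `CSc1ccc(Cc2nn(-c3ccccc3)c(=O)c3ccccc23)cc1`: > 100000 nM
Compound 2 `C=CCn1nc(Cc2ccc(OC)cc2)c2ccccc2c1=O`: "not determined" (no result reported)

In a functional assay on aorta with Alpha-1D adrenergic receptor (Rattus norvegicus) as the target (a lower number here means that less compound is needed, a higher number that more compound is needed for the effect), compound 1 reaches only a limit, > 100000 nM, not a number. This is the limit of > 100000 nM in this assay, at which 1 of the 2 values shown sits. For compound 2 no result exists. Compound 3 `CSc1ccc(Cc2nn(C)c(=O)c3ccccc23)cc1` differs from compound 1 by a methyl in place of phenyl on an aromatic nitrogen, (methyl in place of phenyl on an aromatic nitrogen). Among the compounds with values here, no measured pair shows what such a change does here, and compound 1 gives no number to build from. For compound 3 the expected step of a number no higher from compound 1 to compound 3 (the limit leaves the size open) is therefore none beyond the scatter. Compound 3 is estimated at 100000 nM, within 20000 nM to 500000 nM, most likely again only a limit.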

Compound 3, half-maximal effective concentration: 930 nM
Compound 3: the middle estimate sits 110-fold (2.03 log units) above what was measured, and the stated range ends above it.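

In this assay, the group on this aromatic nitrogen makes a large difference for this pair: methyl in place of phenyl gives an at least 100-fold lower number from compound 1 to compound 3 (2.03 log units; beyond the scatter). Compound 3 thus provides the only real number among the compounds shown. The full size of the step cannot be read, since compound 1 stands at a limit of the assay: the limit of > 100000 nM in this assay, at which 1 of the 3 values shown sits.

Going by these compounds, whether an ethyl, a longer chain or a benzyl on this nitrogen would behave more like the methyl or the phenyl stays open. Compound 2 has no result, so it adds nothing on this.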